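The source may hold more compounds than are shown below. What is called first, only, known or untested is meant among the compounds shown, and "the series" means these compounds.

In a functional assay (Homo sapiens) for inhibition (on this read-out higher numbers stand for weaker inhibition and lower numbers for stronger inhibition), compound 2 `CCCCOc1ccccc1C(=O)/C=C/c1cc(OC)cc(OC)c1` gives 13000 nM. This lies within the scatter of compound 3 `COc1cc(/C=C/C(=O)c2ccc([N+](=O)[O-])cc2)cc(OC)c1` at 20000 nM, while compound 1 `O=C(/C=C/c1ccc(F)cc1)c1ccc(C2CCCCC2)cc1` gives 74000 nM, the weaker inhibition of the three, and its gap to compound 2 lies beyond the scatter. Compound 4 `COc1cc(/C=C/C(=O)c2ccccc2O)cc(OC)c1` keeps the core of compound 2 but carries hydrogen in place of butyl on an oxygen on an aromatic ring, butoxy to hydroxy (hydrogen in place of butyl on an oxygen on an aromatic ring). Among the measured compounds shown here, no measured pair isolates this change. Compound 3, which lacks the butoxy group, still reaches 20000 nM, so no large loss is expected in this assay. The expected step of a 1.5-fold higher number from compound 2 to compound 4 (0.19 log units; within the scatter) is towards a slightly higher number, none beyond the scatter. For compound 4 the estimated value is 20000 nM, with an expected range from 6000 nM to 70000 nM.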

Compound 4, half-maximal inhibitory concentration: 8100 nM
Compound 4: middle estimate off by 2.5-fold (0.39 log units), on the high side; low and high end bracket the measured number.
By their numbers in this assay, from the lowest: compounds 4, 2 and 3 (each within the scatter of the next, the first and the last beyond it); then compound 1.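

Among the compounds shown here, the first pair to isolate this change shows that in this assay, replacing butoxy with hydroxy gives a 1.6-fold lower number from compound 2 to compound 4 (0.21 log units; within the scatter). At this position, the butyl group can therefore be removed without a shift beyond the scatter, and a free hydroxy serves as well as butoxy on this read-out. Nothing given here accounts for this result. As far as these compounds go, it remains open whether a methoxy group or a longer chain on this oxygen, or an amine in place of the hydroxy, would move the number beyond the scatter.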